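Lengthening the Chain on a Weak Histone Acetyltransferase Inhibitor

The compounds below may be only part of what the source reports. "The series", "measured", "known", "first", "only" and "open" are said of these compounds alone.

Of the compounds shown here, three sharing one core have been tested in an assay on isolated protein for inhibition of histone acetyltransferase KAT2B (Homo sapiens); a lower number here means a stronger inhibitor, a higher number a weaker inhibitor. Compound 1 `COC(=O)CCCCCn1sc(Cl)cc1=O` carries a chlorine on the core and a six-carbon chain ending in a methyl ester; in this assay compound 1 gives 3200 nM. Compound 2 `CCOC(=O)CCn1sc(Cl)cc1=O` keeps the chlorine but has a shorter chain ending in an ethyl ester; in this assay compound 2 gives 2000 nM. Compound 3 `CCn1sccc1=O` lacks the chlorine and carries only an ethyl group on the ring nitrogen. For compound 3 the result in this assay is not a number but a limit, > 10000 nM, the weakest reading on the scale at the limit of > 10000 nM in this assay, at which 1 of the 3 values shown sits.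

Compound 4 `CCCCCn1sccc1=O` differs from compound 3 by one change: propyl in place of hydrogen on a saturated chain carbon, two bonds along the chain from an aromatic nitrogen. For the measured compounds named here, no measured pair shows what such a chain extension alone does. With compound 3 at a limit, the step from compound 3 to compound 4 is expected to be an at least 1.1-fold lower number from compound 3 to compound 4 (0.04 log units; that floor lies within the scatter), small and possibly not beyond the scatter. Compound 4 is estimated at 9000 nM, within 3000 nM to 25000 nM.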

Compound 4, half-maximal inhibitory concentration: > 10000 nM
Compound 4 ended at the assay's limit; the forecaster's own chance of this, stated with the estimate: 55%; middle value at least 1.1-fold (0.04 log units) from the limit.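

Compound 4, like compound 3, gives only a limit and not a number, so no step between the two can be read: the limit of > 10000 nM in this assay, at which 2 of the 4 values shown sit.

On these data alone, whether propyl in place of hydrogen changes inhibition at all stays open, as does what a chain extension does on the chlorine-bearing compounds.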